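A few compounds are considered here, and "the series" means these few. Any claim that something is new, unique, unknown or untested is made for them only; others in the source may bear on it.

In a physicochemical assay for lipophilicity (on this read-out lower numbers stand for lower lipophilicity and higher numbers for higher lipophilicity), compound 1 `CNc1ccc(-c2nc3ccc(O)cc3s2)cn1` gives 1.8 and compound 2 `CN(C)c1ncc(-c2nc3ccc(O)cc3s2)cn1` gives 2.2. Compound 2 thus holds the higher of the two numbers, and its gap to compound 1 lies beyond the usual scatter. Compound 3 `CNc1ncc(-c2nc3ccc(O)cc3s2)cn1` has not yet been measured. It differs from compound 2 by a single change, (hydrogen in place of methyl on a nitrogen on an aromatic ring), with hydrogen in place of methyl on a nitrogen on an aromatic ring, so that dimethylamino becomes methylamino. Among the compounds with values here, no measured pair of compounds shows this change on its own, so any expectation in this assay rests on indirect evidence. Within the data shown here, compound 1 also carries methylamino but differs elsewhere as well, and its 1.8 is the only guide. A fall somewhat beyond the scatter is expected, estimated as a number 0.40 log units lower from compound 2 to compound 3 (beyond the scatter). Compound 3 is estimated at 1.8, with an expected range of 1.5 to 2.1.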

Compound 3, distribution coefficient: 0.9
For compound 3 the middle estimate is 0.90 log units above the measured one; the whole stated range lies above it.
By their numbers in this assay, from the lowest: compound 3; then compound 1; then compound 2.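

In this assay, within the data shown here, the change from dimethylamino to methylamino can now be read on its own for the first time: hydrogen in place of methyl on a nitrogen on an aromatic ring gives a number 1.30 log units lower from compound 2 to compound 3 (beyond the scatter). At this place, then, the loss of a single methyl, one carbon with no net charge, goes with a step of considerable size on this read-out, and the shared core stays the same throughout. The compounds shown offer no measurement that accounts for the size of this step.

On these data alone, whether the same change gives a step of this size on another core stays open, since this single pair is the only one that shows it. Also open, as far as these compounds go, is where an unsubstituted amino group, a longer chain such as ethyl, or a morpholine at this place would stand in this assay.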